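A Pyrimidine in Place of a Pyridine

This account rests on a few compounds, and the source may have more. Where it says the series, first, only, none or still open, it means among the compounds named here.

Compound 1 `CO[C@@H]1CC=C2NN(c3cccnc3)C(=O)C[C@]2(C)O1` was tested in a functional assay on A549 cells (Homo sapiens) for inhibition, read by sulforhodamine B assay, with a stated time of 48 h (on this read-out lower numbers stand for stronger inhibition and higher numbers for weaker inhibition), where compound 1 gives 14400 nM. Among the three numbers recorded this is the highest. Compound 2 `CO[C@@H]1CC=C2NN(c3cc4ccccc4[nH]3)C(=O)C[C@]2(c2ccccc2)O1` gives 8670 nM in this assay, a value within the scatter of compound 1. Compound 3 `COc1cc(OC)cc(N2NC3=CC[C@@H](OC)O[C@@]3(c3ccncc3)CC2=O)c1` gives 6220 nM in this assay, a number that lies beyond the scatter from compound 1. Going by the values given here, no two of these measured compounds differ in a single place, so no single-change step among them can be read.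

Compound 4 `CO[C@@H]1CC=C2NN(c3cncnc3)C(=O)C[C@]2(C)O1` has not yet been measured. It differs from compound 1 by pyrimidin-5-yl in place of pyridin-3-yl on an amide-type nitrogen in a ring. Among the compounds with values here, with no measured step of this kind to lean on, the change expected in this assay is none beyond the scatter, with a slight lean toward a weaker inhibition. The estimated step is a 1.1-fold higher number from compound 1 to compound 4 (0.05 log units; within the scatter). Compound 4 is therefore expected to give about 16000 nM, within a range from 7000 nM to 40000 nM.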

Compound 4, half-maximal inhibitory concentration: 4100 nM
Beside the measured number, compound 4's estimate is 3.9-fold (0.59 log units) above it, outside the stated range (below it).
By their numbers in this assay, from the lowest: compounds 4, 3, 2 and 1 (each within the scatter of the next, the first and the last beyond it).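

In this assay, going by these compounds alone, the exchange of pyridin-3-yl for pyrimidin-5-yl on the amide-type nitrogen gives the first single-change step in this set, a 3.5-fold lower number from compound 1 to compound 4 (0.55 log units; beyond the scatter), which points to stronger inhibition. It shows that this position responds to a change within the aromatic ring alone: the heavy-atom count stays the same, one ring carbon gives way to a nitrogen, and the rest of the core of compound 1 is untouched. Nothing measured here bears on why the number falls.

This single step cannot show whether the gain would hold on a core carrying a phenyl in place of the methyl group. It also leaves open how an amine or a carboxylic acid on the pyrimidin-5-yl ring would change the number.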